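Shortening the Long Chain of Compound 1

A few compounds are considered here, and "the series" means these few. Any claim that something is new, unique, unknown or untested is made for them only; others in the source may bear on it.

Among the compounds with values here, in a functional assay on HEL cells (Homo sapiens) (on this read-out higher numbers stand for lower toxicity in this test and lower numbers for higher toxicity in this test), compound 1 (`CCCCCCCCCCCc1cc2cn(COCCO)c(O)nc-2n1`) gives 41000 nM, the lower of the two numbers measured so far. Compound 2 (`CCCCCCCc1cc2cn(COCCO)c(=O)nc2o1`) gives 140000 nM, a number beyond the usual scatter from that of compound 1, which makes compound 1 the more toxic of the pair. The next compound to be tested is compound 3 (`CCCCCc1cc2cn(COCCO)c(O)nc-2n1`), which shares the core of compound 1. The structural change is hydrogen in place of hexyl on a saturated chain carbon, five bonds along the chain from an aromatic carbon. Within the data shown here, no measured pair isolates this change, so the forecast rests on thin evidence. Among the measured compounds shown here, compound 1 already holds the lower of the two numbers, and the only other reading, from compound 2 at 140000 nM, lies above it. A rise beyond the scatter in this assay, towards lower toxicity, is therefore expected. The estimated change is a 2.7-fold higher number from compound 1 to compound 3 (0.43 log units; beyond the scatter). For compound 3 the expected value is 110000 nM, within an estimated range of 45000 nM to 280000 nM.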

Compound 3, half-maximal cytotoxic concentration: > 200000 nM
Compound 3 was reported as a limit; the forecaster's own chance of this, stated with the estimate: 25%; middle value at least 1.8-fold (0.25 log units) away from the limit.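

In this assay, hydrogen in place of hexyl on a saturated chain carbon, five bonds along the chain from an aromatic carbon, gives an at least 4.8-fold higher number from compound 1 to compound 3 (0.68 log units; beyond the scatter), beyond the scatter and towards lower toxicity in this test, and this is the only pair shown that isolates one change on the shared core. For compound 3, the reading of > 200000 nM is a limit of the assay and not a number. The step therefore fixes the direction of the change and only a minimum for its size: the limit of > 200000 nM in this assay, at which 1 of the 3 values shown sits.

On these data alone, how the read-out moves at chain lengths between those of compound 1 and compound 3 remains open, as does how far compound 3 truly lies from compound 1. Also open, as far as these compounds go, is what a longer chain, or an amine or a carboxylic acid in place of hexyl on that saturated chain carbon, would do to the read-out in this assay.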